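This account rests on a few compounds, and the source may have more. Where it says the series, first, only, none or still open, it means among the compounds named here.

Measured compounds in a functional assay on DLD-1 cells (Homo sapiens) for antiproliferative activity, read by CellTiter-Glo, with a stated time of 72 h; a higher number here means a weaker inhibitor, a lower number a stronger inhibitor:
compound 1, `CC1CCN(C2CCN(S(=O)(=O)c3cccc4ccccc34)CC2)CC1`: 0.65 nM
compound 2, `CC1CCN(C2CCN(S(=O)(=O)c3cccc(-c4ccccc4F)c3)CC2)CC1`: 10 nM
compound 3, `CC1CCN(C2CCN(S(=O)(=O)c3cccnc3F)CC2)CC1`: > 5000 nM, a limit of the assay and not a number

The shared core carries a sulfonyl sulfur on a sulfonamide nitrogen in a ring; the three compounds differ only in the aryl group on that sulfur. Compound 1 and compound 2 both give numbers in this assay, and compound 1 sits lower than compound 2. For the measured compounds named here, for compound 3 there is only a limit, (the limit of > 5000 nM in this assay, at which 1 of the 3 values shown sits); compound 3 is the one compound of the three that gives no number.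

Compound 4, `CC1CCN(C2CCN(S(=O)(=O)c3ccc(Cl)c(Cl)c3)CC2)CC1`, is not yet measured. It differs from compound 3 in one place: 3,4-dichlorophenyl in place of 2-fluoropyridin-3-yl on a sulfonyl sulfur. Going by the values given here, no step between measured compounds is available, so the size of the step can only be judged from the three values shown. The two aryl groups without a ring nitrogen, in compound 1 and compound 2, give numbers well inside the working range of this assay, whereas compound 3 gives only a limit. Compound 4 is therefore expected to return a number rather than a limit, with the expected step of an at least 250-fold lower number from compound 3 to compound 4 (2.39 log units; beyond the scatter) being large and in the direction of stronger inhibition. The estimate for compound 4 is 20 nM, with a range from 2 nM to 200 nM.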

Compound 4, half-maximal inhibitory concentration: 2.9 nM
Estimate against measurement, compound 4: 6.9-fold (0.84 log units) above, and the stated range covers the measured number.
By their numbers in this assay, from the lowest: compound 1; then compound 4; then compound 2. At a limit, above all of these: compound 3.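

In this assay, 3,4-dichlorophenyl in place of 2-fluoropyridin-3-yl on a sulfonyl sulfur gives an at least 1700-fold lower number from compound 3 to compound 4 (3.23 log units; beyond the scatter), so this position can separate a compound with a low number from one with only a limit, even when the change is confined to a single aryl group. Both groups are one six-membered aromatic ring, so ring count alone does not distinguish this pair, and compound 4, at 2.9 nM, shows that one ring of carbon only can give a low number here without the larger aryl groups of compound 1 and compound 2. Compound 3 stands at a limit of the assay and not at a number, so the step is open-ended on one side: the limit of > 5000 nM in this assay, at which 1 of the 4 values shown sits.

The ring nitrogen, the fluorine and the two chlorines all change together in this step, which leaves open how much of it belongs to each. Going by these compounds, an unsubstituted phenyl, a phenyl with a single chlorine or a pyridine ring carrying chlorine would pull these apart, and the response to an amine or a carboxylic acid on the aryl group also remains open.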